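Trifluoromethyl for fluoro on the sulfonyl aryl of compound 3

This account rests on a few compounds, and the source may have more. Where it says the series, first, only, none or still open, it means among the compounds named here.

Of the compounds shown here, three have been measured in a functional assay on MDA-MB-231 cells (Homo sapiens) for inhibition, read by sulforhodamine B assay, tested at 10 uM; on this read-out higher numbers stand for more inhibition at the one concentration tested (going by the name of the read-out) and lower numbers for less inhibition. Compound 1, `CN1CCN(c2ccc(C3=NN(S(=O)(=O)c4ccc(C(F)(F)F)cc4)C(c4ccc(N(C)C)cc4)C3)cc2)CC1`, gives 12.1%. Compound 2, `CN(C)c1ccc(C2CC(c3ccc(-n4cncn4)cc3)=NN2S(C)(=O)=O)cc1`, gives 7.8%. Compound 3, `CN(C)c1ccc(C2CC(c3ccc(-n4cncn4)cc3)=NN2S(=O)(=O)c2ccc(F)cc2)cc1`, gives 12.1%, level with compound 1 at the digits printed and, with it, the highest of the three numbers, though all three sit low. Among the measured compounds shown here, the one step measured, a number 4.3 percentage points higher from compound 2 to compound 3 (within the scatter), stays within the scatter.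

Compound 4, `CN(C)c1ccc(C2CC(c3ccc(-n4cncn4)cc3)=NN2S(=O)(=O)c2ccc(C(F)(F)F)cc2)cc1`, differs from compound 3 by trifluoromethyl in place of fluoro on an aromatic carbon. For the measured compounds named here, no measured step bears directly on this change. Going by the values given here, the only related comparison is between compound 1, which carries the trifluoromethyl group on its sulfonyl aryl on a different core, and compound 3, and the two values show no difference at the digits printed. The step from compound 2 to compound 3 shows that replacing the sulfonyl group on this core moves the number only within the scatter. Compound 4 is therefore expected to stay close to compound 3, with a step of a number 0.1 percentage points lower from compound 3 to compound 4 (within the scatter) expected in this assay, none beyond the scatter. The estimate for compound 4 is 12%, within a range from 2% to 24%.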

Compound 4, a percentage reported as inhibition, at one concentration (the size of the read-out at that concentration, not a potency): 15.3%
Estimate against measurement, compound 4: 3.3 percentage points below; the measured number falls inside the stated range.
By their numbers in this assay, from the lowest: compounds 2, 1, 3 and 4 (each within the scatter of the next).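

On the shared core, the direct comparison of trifluoromethyl with fluoro on the sulfonyl aryl gives a step in this assay that stays within the scatter (a number 3.2 percentage points higher from compound 3 to compound 4 (within the scatter)), so at this position the exchange of 4-fluorophenyl for 4-(trifluoromethyl)phenyl does not separate the two compounds. The wider exchange at the sulfonyl sulfur, with 4-(trifluoromethyl)phenyl in place of methyl, also stays within the scatter (a number 7.5 percentage points higher from compound 2 to compound 4 (within the scatter)), as does the first measured change away from the sulfonyl group, 1H-1,2,4-triazol-1-yl in place of 4-methylpiperazin-1-yl with the sulfonyl aryl held the same (a number 3.2 percentage points higher from compound 1 to compound 4 (within the scatter)). Nothing shown here offers an account of these small steps.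

The compounds shown leave open whether a nitrile, a methoxy group or an amine on the sulfonyl aryl would give a step beyond the scatter, since only fluoro and trifluoromethyl occupy that place. They also leave open whether a carboxylic acid or a longer chain in place of the 1H-1,2,4-triazol-1-yl group would move the number in this assay any further.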